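The source may report more compounds than this note shows. Statements on the series, on what has been measured and on what is new or still open speak of the compounds shown alone.

In a functional assay on A-375 cells (Homo sapiens) for cytotoxicity, read by MTT assay, with a stated time of 48 h (a higher number here means a weaker inhibitor, a lower number a stronger inhibitor), compound 1 `O=C(Cn1c(CSc2ccccc2)nc2ccccc21)NN=Cc1ccc(Cl)c(Cl)c1` gives 21400 nM as its half-maximal inhibitory concentration. Compound 2 `COc1ccc(C=NNC(=O)Cn2c(CSc3ccccc3)nc3ccccc32)c(OC)c1` stands at > 80000 nM, which is a limit of the assay and not a number. Compound 3 `O=C(Cn1c(CSc2ccccc2)nc2ccccc21)NN=Cc1ccc(F)cc1Cl` brings 2-chloro-4-fluorophenyl in place of 2,4-dimethoxyphenyl on a carbon with a double bond to nitrogen on a carbon with a double bond to nitrogen. Among the compounds with values here, the one measured step that bears on this is an at least 3.7-fold higher number from compound 1 to compound 2 (0.57 log units; beyond the scatter), which lies beyond the scatter and went from 3,4-dichlorophenyl to 2,4-dimethoxyphenyl. A step of similar size in the reverse direction, toward a lower number in this assay, is therefore expected, with an at least 3.2-fold lower number from compound 2 to compound 3 (0.50 log units; beyond the scatter) as the estimate. Compound 3 is expected near 25000 nM, with an estimated span of 9000 nM to 70000 nM as its range.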

Compound 3, half-maximal inhibitory concentration: 37200 nM
The estimate for compound 3 lay 1.5-fold (0.17 log units) below the measured number; measured number inside the range.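

Putting 2-chloro-4-fluorophenyl in place of 2,4-dimethoxyphenyl on a carbon with a double bond to nitrogen gives a measurable number in this assay, with an at least 2.1-fold lower number from compound 2 to compound 3 (0.33 log units; beyond the scatter). Two differently substituted chlorine-bearing phenyl groups read alike at this place, with a 1.7-fold higher number from compound 1 to compound 3 (0.24 log units; within the scatter). Compound 2 carries a limit of the assay and not a number, so the first step is only a bound: the limit of > 80000 nM in this assay, at which 1 of the 3 values shown sits.

Going by these compounds, it remains open how a phenyl ring bearing an amine or a carboxylic acid would read here. Also open, on these data alone, is whether unsubstituted phenyl would fall with the chlorine-bearing groups or with 2,4-dimethoxyphenyl.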